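The source may hold more compounds than are shown below. What is called first, only, known or untested is meant among the compounds shown, and "the series" means these compounds.

Working notes on the series, read in an ADME assay on L1210/0 cells (Mus musculus) for cytotoxicity, with a stated time of 48 h; a higher number here means a weaker inhibitor, a lower number a stronger inhibitor. Among the compounds with values here, compound 1 `O=c1[nH]c(=O)n([C@H]2C[C@H](O)[C@@H](CO)O2)cc1CO` gives 9180 nM, the only true number so far. Compound 2 `N#Cc1cn([C@H]2C[C@H](O)[C@@H](CO)O2)c(=O)[nH]c1=O` gives > 200000 nM, which is a limit of the assay and not a number. The upper end of the data is therefore (the limit of > 200000 nM in this assay, at which 1 of the 2 values shown sits).

The next change removes the cyano of compound 2 and puts 3-methoxyprop-1-yn-1-yl in its place, on an aromatic carbon of a six-membered aromatic ring with 2 nitrogen, giving compound 3 `COCC#Cc1cn([C@H]2C[C@H](O)[C@@H](CO)O2)c(=O)[nH]c1=O` (3-methoxyprop-1-yn-1-yl in place of cyano on an aromatic carbon).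

Within the data shown here, one measured step bears on this: an at least 21-fold higher number from compound 1 to compound 2 (1.33 log units; beyond the scatter), large and beyond the scatter, with cyano entering in place of hydroxymethyl. It shows that a swap of this group can move the number strongly, but it says nothing direct about the new chain. With compound 2 known only as a limit, a modest move toward a lower number is expected, and the reading may well stay at the limit. The expected step is an at least 2.2-fold lower number from compound 2 to compound 3 (0.34 log units; beyond the scatter). For compound 3 the estimated value is 90000 nM, with an expected range of 20000 nM to 200000 nM.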

Compound 3, half-maximal inhibitory concentration: > 200000 nM
Compound 3: no number, only a limit; the forecaster's own chance of this, stated with the estimate: 50%; at least 2.2-fold (0.34 log units) between middle value and limit.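

Compound 3 gives a limit of the assay and not a number in this assay, as compound 2 does, so the step between these two compounds cannot be read and neither group can be ranked against the other. The new finding is that a second replacement of hydroxymethyl on this aromatic carbon, now with a group of a different size and atom make-up, also leaves the measurable range, with 3-methoxyprop-1-yn-1-yl giving an at least 21-fold higher number from compound 1 to compound 3 (1.33 log units; beyond the scatter). Hydroxymethyl thus remains the only group at this position with a true number, and the upper end of the data now reads: the limit of > 200000 nM in this assay, at which 2 of the 3 values shown sit.

The compounds shown do not tell how far past the limit compound 2 or compound 3 lies, so the ether chain and the nitrile cannot be separated. Also open, on these data alone, is how an amine or a carboxylic acid on this carbon would read, and whether a propynyl chain ending in a free hydroxyl instead of the methoxy would return to a true number.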